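Cyano group retained, ring group enlarged: compound 2 to compound 3

The source may hold more compounds than are shown below. What is called first, only, known or untested is meant among the compounds shown, and "the series" means these compounds.

Two compounds on one shared core have numbers in a functional assay (aorta) with Rattus norvegicus as the target, in the presence of a further agent that is not named here; a higher number here means that more compound is needed for the effect, a lower number that less compound is needed. Compound 1 `COC(=O)C1=C(C)N=C(C)/C(=C(/O)OC)C1c1cccc(OCc2no[n+]([O-])c2C(N)=O)c1` gives 710 nM, and compound 2 `COC(=O)C1=C(C)N=C(C)/C(=C(/O)OC)C1c1cccc(OCc2nonc2C#N)c1` gives 310 nM, the lower of the two numbers.

Compound 3 `COC(=O)C1=C(C)N=C(C)/C(=C(/O)OC)C1c1cccc(OCc2c(C#N)no[n+]2[O-])c1` keeps the core and the nitrile of compound 2 but changes the ring group on the saturated chain carbon bound to an oxygen on an aromatic ring: a group of 8 heavy atoms (3 carbon, 3 nitrogen, 2 oxygen; one five-membered aromatic ring with 3 hetero atoms) in place of a group of 7 heavy atoms (3 carbon, 3 nitrogen, 1 oxygen; one five-membered aromatic ring with 3 hetero atoms), on a saturated chain carbon bound to an oxygen on an aromatic ring.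

For the measured compounds named here, only one measured step bears on this change: a 2.3-fold lower number from compound 1 to compound 2 (0.36 log units; beyond the scatter), modest but beyond the scatter. Going by the values given here, it is an imperfect guide, since compound 1 carries no nitrile and that step therefore changes more than the present one does. Still, the group entering compound 3 lies between those of compound 2 and compound 1 in size, so only part of that step might return. A small rise in this assay is expected, probably not beyond the scatter. The expected change is a 1.3-fold higher number from compound 2 to compound 3 (0.11 log units; within the scatter). Compound 3 is estimated at 400 nM, with an expected range of 140 nM to 1100 nM.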

Compound 3, half-maximal effective concentration: 11 nM
For compound 3 the middle estimate is 36-fold (1.56 log units) above the measured one; measured number below the stated range.
By their numbers in this assay, from the lowest: compound 3; then compound 2; then compound 1.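

In this assay, this position proves far more sensitive than the earlier pair suggested: the ring group on the saturated chain carbon bound to an oxygen on an aromatic ring gives a 28-fold lower number from compound 2 to compound 3 (1.45 log units; beyond the scatter), although the nitrile is kept and the donor and acceptor counts of the two groups are the same. Group size does not order the series, since a 65-fold lower number from compound 1 to compound 3 (1.81 log units; beyond the scatter) and compound 3 carries the mid-sized group of the three, while the smallest and largest groups, in compound 2 and compound 1, both give higher numbers. The nitrile alone therefore does not set the number, and no measurement shown here explains the effect of this change.

Compound 1 and compound 3 differ in the ring group as well as in the nitrile-bearing substituent, so the shares of these two features in their gap remain unseparated. Also open, on these data alone, is whether the low number of compound 3 persists with a methyl ester or a phenylsulfonyl group in place of the nitrile, or with a longer chain linking the ring group to the oxygen on the aromatic ring.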